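Shifting a biphenyl substituent in a thromboxane receptor antagonist series

The source may report more compounds than this note shows. Statements on the series, on what has been measured and on what is new or still open speak of the compounds shown alone.

Of the compounds shown here, three sharing one core have been measured in a functional assay on blood for antagonist activity at thromboxane A2 receptor (Homo sapiens); a lower number here means tighter binding, a higher number weaker binding. Compound 1 `CC(=O)NCc1ccccc1-c1ccc(COC2CC[C@H](N3CCCCCC3)[C@H]2OC/C=C\CCC(=O)O)cc1` gives 25.1 nM in this assay. Compound 2 `O=C(O)CC/C=C\CO[C@@H]1C(OCc2ccc(-c3ccccc3)cc2)CC[C@@H]1N1CCCCC1` gives 39.8 nM in this assay, a number that sits within the scatter of that of compound 1, so no order can be read between the two. Compound 3 `O=C(O)CC/C=C\CO[C@H]1[C@H](OCc2ccc(-c3ccccc3CO)cc2)CC[C@@H]1N1CCCCCC1` gives 6.31 nM in this assay, a lower number than that of compound 1 by a margin that lies beyond the scatter. Compound 1 thus holds the second highest number of the three, with compound 2 nearest and compound 3 furthest from it.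

Compound 4 `CS(=O)(=O)Nc1cccc(-c2ccc(COC3CC[C@H](N4CCCCCC4)[C@H]3OC/C=C\CCC(=O)O)cc2)c1` has not yet been measured in this assay. It differs from compound 1 in one place: 3-(methanesulfonamido)phenyl in place of 2-(acetamidomethyl)phenyl on an aromatic carbon. Among the measured compounds shown here, no pair of measured compounds differs in just one place, so no step of this kind has been seen, and the three values together leave the direction open. The change from compound 1 to compound 4 is expected to give a step of a 1.3-fold lower number from compound 1 to compound 4 (0.10 log units; within the scatter), that is, none beyond the scatter. Compound 4 is therefore expected to give about 20 nM in this assay, in a range from 6.3 nM to 63 nM.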

Compound 4, dissociation constant: 12.6 nM
Compound 4: the middle estimate sits 1.6-fold (0.20 log units) above what was measured; the measured number falls inside the stated range.
By their numbers in this assay, from the lowest: compounds 3, 4, 1 and 2 (each within the scatter of the next, the first and the last beyond it).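

In this assay, among the compounds shown here, the exchange of 2-(acetamidomethyl)phenyl for 3-(methanesulfonamido)phenyl gives a 2.0-fold lower number from compound 1 to compound 4 (0.30 log units; within the scatter) as the first step that can be read at a single place. This place, on an aromatic carbon para to a large group, therefore takes either of these two groups, each of 11 heavy atoms and carrying a hydrogen-bond donor, with no order to be read between compound 1 and compound 4, even though the entering group brings in sulfur and a second hydrogen-bond acceptor. No measurement offered here accounts for this outcome.

The step alters the group and its location on the ring together, so what each of the two contributes on its own stays unresolved, and a single step cannot show whether the tolerance holds more widely at this place. Going by these compounds, how a carboxylic acid, a primary amine or a simple methoxy group would behave on this ring in this assay also remains open.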